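Bromo in place of methoxy on compound 3

This account rests on a few compounds, and the source may have more. Where it says the series, first, only, none or still open, it means among the compounds named here.

Compound 1 `S=C(Sc1ccccc1)N1CCCCC1` gives 7930 nM
Compound 2 `S=C(Sc1ccccc1)N1CCOCC1` gives 2520 nM
Compound 3 `COc1ccc(SC(=S)N2CCN(C(=O)OC(C)(C)C)CC2)cc1` gives 712 nM

All three compounds were tested in a functional assay on A549 cells (Homo sapiens) for antiproliferative activity, read by MTT assay, with a stated time of 72 h; on this read-out higher numbers stand for weaker inhibition and lower numbers for stronger inhibition. Compound 3 has the lowest number of the three and so shows the strongest inhibition. Its distance from compound 2 and its larger distance from compound 1 both lie beyond the scatter. Compound 3 differs from each of the other two in more than one place, so these gaps cannot be assigned to any single part of the structure.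

The next compound is compound 4 `CC(C)(C)OC(=O)N1CCN(C(=S)Sc2ccc(Br)cc2)CC1`, which keeps everything in compound 3 except for one group. The change is bromo in place of methoxy on an aromatic carbon, para to a large group. Within the data shown here, no measured pair shows what a change at this place does in this assay, so the expectation has little to rest on. Among the measured compounds shown here, it is anchored on compound 3 (712 nM), the only measured compound that shares the rest of the structure. The expected result is a step of a 1.2-fold lower number from compound 3 to compound 4 (0.07 log units; within the scatter) that stays within the scatter, with no firm direction. The estimate for compound 4 is 600 nM, with an expected range from 200 nM to 1800 nM.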

Compound 4, half-maximal inhibitory concentration: 1820 nM
Compound 4: middle estimate off by 3.0-fold (0.48 log units), on the low side, and the stated range ends below it.
By their numbers in this assay, from the lowest: compound 3; then compounds 4 and 2 (each within the scatter of the next); then compound 1.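

In this assay, among these compounds, the exchange of methoxy for bromo gives a 2.6-fold higher number from compound 3 to compound 4 (0.41 log units; beyond the scatter) with the rest of the structure held fixed, and this is the first comparison that isolates a single place. It shows that the substituent on this aromatic carbon, para to a large group, matters in this assay, and that of the two groups seen here, the 4-methoxyphenyl compound carries the lower number and so the stronger inhibition. No measurement at hand bears on why the step occurs.

With only two groups seen at this carbon, the compounds shown cannot tell whether methoxy is unusually good here or bromo is unusually poor, and a single pair sets no trend. An amine, a hydroxyl group or a longer chain such as ethoxy at the same carbon would help to separate these readings, and it also remains open whether the step would hold on the other parts of the structure that vary among the compounds shown.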